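Clearance Outlook for a Dimethylphenyl Sulfone Analogue

This account rests on a few compounds, and the source may have more. Where it says the series, first, only, none or still open, it means among the compounds named here.

Measured so far: compound 1 `Cc1ccc(S(=O)(=O)c2cnc3cc(F)ccc3c2-c2ccc(Cl)cc2)cc1C` gives 7.88 mL/min; compound 2 `N#Cc1cccc(S(=O)(=O)c2cnc3cc(F)ccc3c2-c2cccc(Cl)c2)c1` gives 0.99 mL/min; compound 3 `COc1ccc(S(=O)(=O)c2cnc3cc(F)ccc3c2-c2cccc(Cl)c2)cc1Cl` gives 1.19 mL/min.

In an ADME assay on microsomes from liver (Homo sapiens) for metabolic stability, tested at 2.5 uM (a lower number here means slower removal, a higher number faster removal of the compound), compound 3 stands second highest of the three, close to compound 2 and far from compound 1. Going by the values given here, the one measured step, a 1.2-fold higher number from compound 2 to compound 3 (0.08 log units; within the scatter), was within the scatter. Compound 4 `Cc1ccc(S(=O)(=O)c2cnc3cc(F)ccc3c2-c2cccc(Cl)c2)cc1C` differs from compound 3 by 3,4-dimethylphenyl in place of 3-chloro-4-methoxyphenyl on a sulfonyl sulfur. Among the compounds with values here, no measured step covers this change directly; compound 1, which also carries 3,4-dimethylphenyl on the sulfonyl sulfur, shows a much higher number than compound 3. An increase is therefore expected, a 3.4-fold higher number from compound 3 to compound 4 (0.53 log units; beyond the scatter), with broad uncertainty. Compound 4 is estimated at 4 mL/min, ranging from 1.5 mL/min to 10 mL/min.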

Compound 4, intrinsic clearance in a liver preparation (reported as CLH), per the amount of preparation that the assay uses: 4.01 mL/min
Compound 4: middle estimate off by 1.0-fold (0.00 log units), on the low side, within the range that was stated.
By their numbers in this assay, from the lowest: compounds 2 and 3 (each within the scatter of the next); then compounds 4 and 1 (each within the scatter of the next).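

With 3-chlorophenyl held on the core, 3,4-dimethylphenyl on the sulfonyl sulfur gives a change beyond the scatter in this assay, which the earlier step did not show: a 3.4-fold higher number from compound 3 to compound 4 (0.53 log units; beyond the scatter) and a 4.1-fold higher number from compound 2 to compound 4 (0.61 log units; beyond the scatter). Replacing 4-chlorophenyl with 3-chlorophenyl on an aromatic carbon gives a 2.0-fold lower number from compound 1 to compound 4 (0.29 log units; within the scatter), so in these compounds the higher numbers follow the 3,4-dimethylphenyl group whichever chlorophenyl is present. Nothing available accounts for this rise. Still open, going by these compounds, is what a phenyl carrying an amine or a carboxylic acid on the sulfonyl sulfur would give in this assay.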